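Pyridin-2-yl in Place of Phenyl at the Ketone

A few compounds are considered here, and "the series" means these few. Any claim that something is new, unique, unknown or untested is made for them only; others in the source may bear on it.

Compound 1 `Cc1ccc(C(=O)CC2CC(=O)N(c3ccc(S(N)(=O)=O)cc3)C2=O)cc1` — 860 nM in an assay on cells (1-87 tumor cell line) for inhibition of Polyunsaturated fatty acid 5-lipoxygenase (Homo sapiens), with a stated time of 5 min; on this read-out lower numbers stand for stronger inhibition and higher numbers for weaker inhibition
Compound 2 `CC1CCC(=O)C(C2CC(=O)N(Cc3ccccc3)C2=O)C1` — 56200 nM in this assay
Compound 3 `NS(=O)(=O)c1ccc(N2C(=O)CC(CC(=O)c3ccccc3)C2=O)cc1` — 5290 nM in this assay

Compound 3 stands second highest of the three numbers: its nearest neighbour is compound 1, reached by a 6.2-fold higher number from compound 1 to compound 3 (0.79 log units; beyond the scatter) through a hydrogen in place of methyl on an aromatic carbon, and its furthest is compound 2, which gives the highest number of the set. Compound 4 `NS(=O)(=O)c1ccc(N2C(=O)CC(CC(=O)c3ccccn3)C2=O)cc1` differs from compound 3 by pyridin-2-yl in place of phenyl on a carbonyl carbon. For the measured compounds named here, no measured step touches this kind of exchange; the only step in hand concerns a methyl on a distant aromatic ring and says nothing about the ketone-side aryl. The expectation for compound 4 in this assay is therefore no step beyond the scatter, with the estimate 5000 nM (range 1500 nM to 16000 nM), meaning an expected step of a 1.1-fold lower number from compound 3 to compound 4 (0.02 log units; within the scatter).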

Compound 4, half-maximal inhibitory concentration: 810 nM
Compound 4: the middle estimate sits 6.2-fold (0.79 log units) above what was measured, outside the stated range (below it).
By their numbers in this assay, from the lowest: compounds 4 and 1 (each within the scatter of the next); then compound 3; then compound 2.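

The aryl group on the ketone carbonyl turns out to be a place that responds in this assay, with pyridin-2-yl in place of phenyl giving a 6.5-fold lower number from compound 3 to compound 4 (0.81 log units; beyond the scatter) for this change. Against the 4-methylphenyl group, pyridin-2-yl gives a 1.1-fold lower number from compound 1 to compound 4 (0.03 log units; within the scatter), so two different replacements of the phenyl of compound 3 arrive at the same level. Nothing at hand explains either step.

From the compounds shown here alone, whether pyridin-3-yl or pyridin-4-yl would hold this level remains open. So does whether a methyl group on the pyridin-2-yl ring would change it.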